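Hydroxy in Place of Nitro: Cytotoxicity on HEL Cells

The compounds below may be only part of what the source reports. "The series", "measured", "known", "first", "only" and "open" are said of these compounds alone.

Compound 3 `Cc1cc(-c2cccc([N+](=O)[O-])c2)cn2c(CSCCc3ccccc3)cnc12` is one of three analogues built on a shared core. In an ADME assay on HEL cells (Homo sapiens) for cytotoxicity, with a stated time of 3 days (on this read-out higher numbers stand for lower toxicity in this test and lower numbers for higher toxicity in this test), compound 3 gives >= 100 ug/mL and that figure is a limit of the assay, not a number. Compound 1 `Cc1cc(-c2cccc(C#N)c2)cn2c(CSCCc3ccccc3)cnc12` gives > 100 ug/mL in the same test and this too is a limit. Compound 2 `Cc1cc(-c2ccc(C#N)cc2)cn2c(CSCCc3ccccc3)cnc12` gives >= 20 ug/mL and that value is likewise a limit. The steps a step that the two limits leave unreadable from compound 1 to compound 2, a step that the two limits leave unreadable from compound 1 to compound 3 and a step that the two limits leave unreadable from compound 2 to compound 3 stay unreadable because of the limit of > 100 ug/mL in this assay, at which 1 of the 3 values shown sits, the limit of >= 100 ug/mL in this assay, at which 1 of the 3 values shown sits, and the limit of >= 20 ug/mL in this assay, at which 1 of the 3 values shown sits, mark where all three values sit. Compound 4 `Cc1cc(-c2cccc(O)c2)cn2c(CSCCc3ccccc3)cnc12` differs from compound 3 by hydroxy in place of nitro on an aromatic carbon as counted above. Within the data shown here, no measured step bears on this exchange. Compound 4 is expected to move by a number no higher from compound 3 to compound 4 (the limit leaves the size open), which is no step beyond the scatter. Compound 4 is estimated at 100 ug/mL, from 50 ug/mL to 200 ug/mL.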

Compound 4, minimum cytotoxic concentration: 20 ug/mL
Compound 4: the middle estimate sits 5.0-fold (0.70 log units) above what was measured; the whole stated range lies above it.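

Hydroxy in place of nitro, on an aromatic carbon meta to a large group, gives an at least 5.0-fold lower number from compound 3 to compound 4 (0.69 log units; beyond the scatter) in this assay. Hydroxy in place of cyano likewise gives an at least 5.0-fold lower number from compound 1 to compound 4 (0.69 log units; beyond the scatter), so two different groups leaving this position give readable steps to compound 4. 3-Hydroxyphenyl in place of 4-cyanophenyl gives a number no higher from compound 2 to compound 4 (the limit leaves the size open), a step whose size cannot be read: the limit of >= 20 ug/mL in this assay, at which 1 of the 4 values shown sits.

The compounds shown leave open whether an amine or a methoxy group at this position would behave like the hydroxy of compound 4 in this assay.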